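Adding a Second Methoxy Group to the Benzyl Ring

A few compounds are considered here, and "the series" means these few. Any claim that something is new, unique, unknown or untested is made for them only; others in the source may bear on it.

The series rests on a shared core with a substituted benzyl group on one end and a substituted phenyl group on the other. In a functional assay on MCF7 cells (Homo sapiens) for antiproliferative activity, read by sulforhodamine B assay, with a stated time of 48 h (a lower number here means a stronger inhibitor of growth, a higher number a weaker inhibitor of growth), compound 1 `COc1ccc(Cn2cc(CNC(=O)c3cn(-c4ccccc4)nc3-c3ccccc3)nn2)cc1OC` gives 12600 nM, and compound 2 `COc1ccc(Cn2cc(CNC(=O)c3cn(-c4ccccc4)nc3-c3ccc(Cl)cc3)nn2)cc1` gives 8000 nM. Compound 2 has the lower of the two numbers, but the gap to compound 1 lies within the scatter, so neither can be ranked above the other. Compound 3 `COc1ccc(Cn2cc(CNC(=O)c3cn(-c4ccccc4)nc3-c3ccc(Cl)cc3)nn2)cc1OC` is still to be measured. It differs from compound 2 by methoxy in place of hydrogen on an aromatic carbon. Compound 1 already carries the same two methoxy groups on its benzyl ring, with no clear separation from compound 2, so the change is expected to move the number little in either direction, if at all beyond the scatter. Compound 3 is therefore estimated at 9000 nM, with a range from 4000 nM to 20000 nM, a step of a 1.1-fold higher number from compound 2 to compound 3 (0.05 log units; within the scatter).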

Compound 3, concentration for 50% growth inhibition: > 100000 nM
Compound 3 gave a limit, no number (the forecaster's own chance of this, stated with the estimate: 5%); middle value at least 11-fold (1.04 log units) away from the limit.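

In this assay compound 3 stands at a limit of the assay and not at a number: the limit of > 100000 nM in this assay, at which 1 of the 3 values shown sits. Going from 4-methoxybenzyl to 3,4-dimethoxybenzyl, with the new methoxy ortho to a methoxy group, gives an at least 12-fold higher number from compound 2 to compound 3 (1.09 log units; beyond the scatter), so this position is not indifferent to the change when chloro is present. Chloro in place of hydrogen on an aromatic carbon gives an at least 7.9-fold higher number from compound 1 to compound 3 (0.89 log units; beyond the scatter), which shows that the 3,4-dimethoxybenzyl compounds also respond strongly to chloro, something the earlier pair could not reveal.

The compounds shown leave open whether a smaller group at this position, such as hydroxyl or fluoro, would carry the same penalty as methoxy. They also leave open how far compound 3 lies beyond its limit.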